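Moving the Bromine: From Compound 2 to Compound 4

The source may report more compounds than this note shows. Statements on the series, on what has been measured and on what is new or still open speak of the compounds shown alone.

Compound 2 `COc1cccc(CSc2nnc(-c3ccc4c(c3)OCCO4)n2-c2ccccc2)c1` gives 10100 nM in a functional assay on SW 1116 cells (Homo sapiens) for antiproliferative activity, read by MTT assay, with a stated time of 24 h (a lower number here means a stronger inhibitor, a higher number a weaker inhibitor), the lowest of the three numbers seen so far. Compound 1 `Clc1cccc(CSc2nnc(-c3ccc4c(c3)OCCO4)n2-c2ccccc2)c1` sits alongside it at 10600 nM, with a 1.0-fold lower number from compound 1 to compound 2 (0.02 log units; within the scatter). Compound 3 `Brc1cccc(CSc2nnc(-c3ccc4c(c3)OCCO4)n2-c2ccccc2)c1` is weaker at 26200 nM. Compound 4 `Brc1ccc(CSc2nnc(-c3ccc4c(c3)OCCO4)n2-c2ccccc2)cc1` has not been measured yet; its change from compound 2 is 4-bromophenyl in place of 3-methoxyphenyl on a saturated chain carbon bound to a sulfur.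

For the measured compounds named here, two measured steps bear on this: a 2.6-fold higher number from compound 2 to compound 3 (0.41 log units; beyond the scatter) and a 2.5-fold higher number from compound 1 to compound 3 (0.39 log units; beyond the scatter). Both swaps put bromine on the ring and both gave a modest loss. Compound 4 carries bromine at a different place on that ring, so the guidance is only indirect, but a step of similar size and direction is expected, namely a 2.2-fold higher number from compound 2 to compound 4 (0.34 log units; beyond the scatter). Compound 4 is therefore estimated at 22000 nM, likely between 9000 nM and 55000 nM.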

Compound 4, half-maximal inhibitory concentration: 5810 nM
Beside the measured number, compound 4's estimate is 3.8-fold (0.58 log units) above it, outside the stated range (below it).
By their numbers in this assay, from the lowest: compounds 4, 2 and 1 (each within the scatter of the next); then compound 3.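

Moving the bromine, 4-bromophenyl in place of 3-bromophenyl, gives a 4.5-fold lower number from compound 3 to compound 4 (0.65 log units; beyond the scatter) and so the loss seen earlier with bromine does not carry over to every bromine-bearing ring. Set against the other two groups, 4-bromophenyl shows a 1.7-fold lower number from compound 2 to compound 4 (0.24 log units; within the scatter) and a 1.8-fold lower number from compound 1 to compound 4 (0.26 log units; within the scatter) and so stands level with both. No measurement shown here explains why the two bromobenzyl groups differ.

From the compounds shown here alone, whether 4-chlorobenzyl or 4-methoxybenzyl would match 4-bromobenzyl stays open. So does the effect of an amine or a carboxylic acid on this ring.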